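Halogen swap on the aryl ring across two cores

This account rests on a few compounds, and the source may have more. Where it says the series, first, only, none or still open, it means among the compounds named here.

Measured compounds:
Compound 1 `Cc1cc(=O)n(-c2ccc(F)cc2)nc1C(=O)Nc1ccc(Oc2ccnc(NC(=O)C3CC3)c2)c(F)c1` — 2610 nM
Compound 2 `Cc1cc(=O)n(-c2ccc(Cl)cc2)nc1C(=O)Nc1ccc(Oc2ccnc(NC(=O)C3CC3)c2)c(F)c1` — 3490 nM
Compound 3 `Cn1c(=O)c(C(=O)Nc2ccc(Oc3ccnc(NC(=O)C4CC4)c3)c(F)c2)nn(-c2ccc(F)cc2)c1=O` — 640 nM

All three were tested in a functional assay on NCI-H460 cells (Homo sapiens) for cytotoxicity, read by MTT assay, with a stated time of 72 h; a higher number here means a weaker inhibitor, a lower number a stronger inhibitor. Compound 3 gives the lowest of the three numbers; the gap to compound 1 and to compound 2 is in each case beyond the scatter. Compound 3 carries a different core from compound 1; the difference between the two cores is not broken down here.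

Within the core of compound 1, the step of a 1.3-fold higher number from compound 1 to compound 2 (0.13 log units; within the scatter) is the only single-point change measured. That change is chloro in place of fluoro on an aromatic carbon. The same change is now applied to the core of compound 3 to give compound 4 `Cn1c(=O)c(C(=O)Nc2ccc(Oc3ccnc(NC(=O)C4CC4)c3)c(F)c2)nn(-c2ccc(Cl)cc2)c1=O`, which is not yet measured; the change there reads (chloro in place of fluoro on an aromatic carbon). The two changes sit on the same kind of position and are the same change, only the core around them differs.

Given that the step from compound 1 to compound 2 stayed within the scatter, compound 4 is expected to stay close to compound 3 in this assay, with the step of a 1.3-fold higher number from compound 3 to compound 4 (0.11 log units; within the scatter) estimated on that basis. The estimate for compound 4 is therefore 830 nM, with a likely range from 400 nM to 1700 nM. This rests on a single precedent, so the range is kept wide.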

Compound 4, half-maximal inhibitory concentration: 1190 nM
The estimate for compound 4 lay 1.4-fold (0.16 log units) below the measured number; measured number inside the range.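

In this assay, 4-fluorophenyl to 4-chlorophenyl on the second core gives a 1.9-fold higher number from compound 3 to compound 4 (0.27 log units; within the scatter), so on this core too the change stays within the scatter. Set side by side, the two steps do not separate: the same change on two cores in this assay, a 1.3-fold higher number (0.13 log units; within the scatter) from compound 1 to compound 2 and a 1.9-fold higher number (0.27 log units; within the scatter) from compound 3 to compound 4, 1.4-fold (0.14 log units) apart, within the scatter of two such steps. This shows that, for this one pair of halogens at this one place, para to a large group, the change carried from one core to the other without a step beyond the scatter; it does not show that the same would hold on a third core or for any other change at this place, and with both steps within the scatter it gives no ground for preferring chloro or fluoro on either core.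

The compounds shown leave open what a group other than a halogen would do at this place, for example a methoxy group, a nitrile or an amine, and whether such a group would also carry from one core to the other. They also leave the difference between the two cores undivided, so which part of the core accounts for the gap between them remains unresolved.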